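Replacing a ring-bearing side group with a ring-free one

The compounds below may be only part of what the source reports. "The series", "measured", "known", "first", "only" and "open" are said of these compounds alone.

In an in vivo functional assay on the whole organism for inhibition, with Rattus norvegicus as the target (on this read-out lower numbers stand for an effect already at smaller amounts and higher numbers for an effect only at larger amounts of compound), compound 1 (`CCCCc1nc(C)c(CC(=O)N2CCCC2)c(=O)n1Cc1ccc(-c2ccccc2-c2nnn[nH]2)cc1`) gives 0.056 mg/kg, compound 2 (`CCCCc1nc(C)c(CCC(=O)N2CCSCC2)c(=O)n1Cc1ccc(-c2ccccc2-c2nnn[nH]2)cc1`) gives 0.204 mg/kg and compound 3 (`CCCCc1nc(C)c(CCC(=O)N2CCCCC2)c(=O)n1Cc1ccc(-c2ccccc2-c2nnn[nH]2)cc1`) gives 0.164 mg/kg. Compound 3 therefore holds the middle place among the three numbers, although the gap on one side lies within the scatter: the exchange of one ring for another gives a 1.2-fold lower number from compound 2 to compound 3 (0.09 log units; within the scatter).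

Compound 4 (`CCCCc1nc(C)c(CC(=S)N(CC)CC)c(=O)n1Cc1ccc(-c2ccccc2-c2nnn[nH]2)cc1`) departs from compound 3 through (a group of 7 heavy atoms (5 carbon, 1 nitrogen, 1 sulfur; no ring) in place of a group of 9 heavy atoms (7 carbon, 1 nitrogen, 1 oxygen; one six-membered non-aromatic ring with 1 hetero atom), on a saturated chain carbon bound to an aromatic carbon). For the measured compounds named here, no measured step makes this exact change, and no measured compound carries the entering group, so its own contribution is unknown. The closest evidence is the step in which the departing ((piperidin-1-yl)carbonyl)methyl group enters, a 2.9-fold higher number from compound 1 to compound 3 (0.47 log units; beyond the scatter). The related ((thiomorpholin-4-yl)carbonyl)methyl group gives a step of similar size, a 3.6-fold higher number from compound 1 to compound 2 (0.56 log units; beyond the scatter). Both are modest and point to higher numbers when these groups enter, so removing the group may reverse part of that rise in this assay. On that limited basis, a modest move to a lower number is expected, a 2.1-fold lower number from compound 3 to compound 4 (0.31 log units; beyond the scatter). For compound 4 the estimated value is 0.08 mg/kg, with an expected range from 0.025 mg/kg to 0.25 mg/kg.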

Compound 4, dose for half-maximal effect: 0.023 mg/kg
Compound 4: middle estimate off by 3.5-fold (0.54 log units), on the high side; measured number below the stated range.
By their numbers in this assay, from the lowest: compound 4; then compound 1; then compounds 3 and 2 (each within the scatter of the next).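

In this assay, the ring-free group of 7 heavy atoms gives compound 4 the lowest number of the four, so a ring in the group at this place, a saturated chain carbon bound to an aromatic carbon, is not required for an effect at small amounts. The fall is seen against the ((piperidin-1-yl)carbonyl)methyl group (a 7.1-fold lower number from compound 3 to compound 4 (0.85 log units; beyond the scatter)) and against the ((thiomorpholin-4-yl)carbonyl)methyl group (an 8.9-fold lower number from compound 2 to compound 4 (0.95 log units; beyond the scatter)). It also persists against the (pyrrolidin-1-yl)carbonyl group, which has the same count of 7 heavy atoms (a 2.4-fold lower number from compound 1 to compound 4 (0.39 log units; beyond the scatter)), so that count alone does not order these compounds, and no measurement that would explain the change is at hand.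

Because the entering group differs from the others at once in having no ring and in carrying sulfur where they carry a carbonyl oxygen, the compounds shown do not separate these two changes. A (diethylamino)carbonyl group at the same place, or a pyrrolidine ring joined through the same sulfur-bearing carbon, would leave only one of them in play.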